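This account rests on a few compounds, and the source may have more. Where it says the series, first, only, none or still open, it means among the compounds named here.

Three compounds sharing one core have been examined in an ADME assay on MDCK cells (Canis lupus familiaris) for cytotoxicity, read by MTT assay, with a stated time of 72 h; a lower number here means that less compound is tolerated, a higher number that more compound is tolerated. Compound 1 `Cc1nc([N+](=O)[O-])cn1S(=O)(=O)c1ccc([N+](=O)[O-])cc1` gives 611000 nM. Compound 2 `Cc1nc([N+](=O)[O-])cn1CC(=O)Nc1cccc(C(F)(F)F)c1` gives 435000 nM, and compound 3 `Cc1nc([N+](=O)[O-])cn1CC(=O)Nc1ccccc1` gives 1140000 nM. Among these three numbers compound 1 stands second highest, and its gap to compound 2 as well as its gap to compound 3 lies within the scatter, so no order can be read among them. Among the compounds with values here, the only step between measured compounds that differ in one place, a 2.6-fold higher number from compound 2 to compound 3 (0.42 log units; beyond the scatter), occurs at a different part of the shared core from the one changed here.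

Compound 4 `Cc1ccc(S(=O)(=O)n2cc([N+](=O)[O-])nc2C)cc1` differs from compound 1 by methyl in place of nitro on an aromatic carbon. Within the data shown here, no measured step touches this part of the core, and no measured pair exchanges a nitro for a methyl, so nothing points toward a higher or a lower number. Given that the one measured step was only modest and the three numbers sit close together, compound 4 is expected to give 650000 nM, within a range of 300000 nM to 1400000 nM. The expected step, a 1.1-fold higher number from compound 1 to compound 4 (0.03 log units; within the scatter), is estimated to stay within the scatter.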

Compound 4, half-maximal cytotoxic concentration: 988000 nM
Estimate against measurement, compound 4: 1.5-fold (0.18 log units) below; low and high end bracket the measured number.
By their numbers in this assay, from the lowest: compounds 2, 1, 4 and 3 (each within the scatter of the next, the first and the last beyond it).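

In this assay, within the data shown here, the exchange of nitro for methyl on this aromatic carbon, para to a large group, offers the first reading at this part of the core (a 1.6-fold higher number from compound 1 to compound 4 (0.21 log units; within the scatter)). The step replaces a group of 3 heavy atoms and 2 hydrogen-bond acceptors with a single carbon carrying no acceptor, yet compound 1 and compound 4 cannot be ordered, so this one exchange shows no clear effect on tolerance in this assay. Nothing at hand bears on the reason for this result.

A single pair cannot show whether this position is insensitive in general or only to this exchange. An amine, a carboxylic acid or a longer chain such as propyl at the same carbon could still give a step beyond the scatter.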